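Changing the Aryl Group on the Amide-Type Nitrogen

The source may hold more compounds than are shown below. What is called first, only, known or untested is meant among the compounds shown, and "the series" means these compounds.

Of the compounds shown here, two have so far been measured in an in vivo ADME assay on the whole organism (plasma) for pharmacokinetics, with Mus musculus as the target, at a dose of 30 mg/kg by the oral route; a lower number here means less compound in the circulation, a higher number more compound in the circulation at the dose given. Compound 1 `COc1cccc(NC(=O)OCCSc2cccc(CSc3nc4ccccc4[nH]3)c2C)c1` gives 1660 nM in this assay, and compound 2 `Cc1c(CSc2nc3ccccc3[nH]2)cccc1SCCNC(=O)c1cnccn1` gives 1080 nM; the two numbers lie within the usual scatter of each other, so neither stands apart from the other. Compound 3 `Cc1c(CSc2nc3ccccc3[nH]2)cccc1SCCOC(=O)Nc1ccc(N(C)C)cc1` has not yet been measured. It differs from compound 1 in one place: 4-(dimethylamino)phenyl in place of 3-methoxyphenyl on an amide-type nitrogen. Nothing else in the molecule changes. For the measured compounds named here, no measured pair shows what this kind of swap does to the amount of compound in the circulation, and compound 2 differs from both in more than one place, so the only anchor is the value of compound 1. The step of a 1.3-fold lower number from compound 1 to compound 3 (0.11 log units; within the scatter) is expected to stay within the scatter, with no clear direction. Compound 3 is therefore estimated at 1300 nM, with a likely range from 500 nM to 3500 nM.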

Compound 3, maximal plasma concentration: 672 nM
Compound 3: middle estimate off by 1.9-fold (0.29 log units), on the high side, within the range that was stated.
By their numbers in this assay, from the lowest: compounds 3, 2 and 1 (each within the scatter of the next, the first and the last beyond it).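

For the compounds shown here, until this result, no pair of compounds isolated this position, so nothing showed whether the aryl group on the amide-type nitrogen affects the outcome in this assay at all. It does: with the rest of the molecule unchanged, putting 4-(dimethylamino)phenyl in place of 3-methoxyphenyl gives a 2.5-fold lower number from compound 1 to compound 3 (0.39 log units; beyond the scatter) and so moves the number beyond the usual scatter, though only modestly. Nothing in the data shown explains why this swap lowers the amount of compound in the circulation.

This single swap alters both the substituent and where it sits on the ring, so the two effects cannot be told apart. A 4-methoxyphenyl group on the same nitrogen would separate them, and an unsubstituted phenyl group would show how either substituent compares with a bare ring.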